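Swapping the pyrrolidine amide for a phenylpiperidine

The compounds below may be only part of what the source reports. "The series", "measured", "known", "first", "only" and "open" are said of these compounds alone.

Three compounds share one core and are compared in a functional assay on CHO-K1 cells for antagonist activity at transient receptor potential cation channel subfamily V member 1 (Homo sapiens), read by FLIPR; a higher number here means a weaker inhibitor, a lower number a stronger inhibitor. Compound 1 `CCCCN(C)c1nc(C(F)(F)F)ccc1CNC(=O)C(C)c1ccc(NS(C)(=O)=O)c(F)c1` gives 21.3 nM in this assay. For the measured compounds named here, compound 2 `C[C@H](C(=O)NCc1ccc(C(F)(F)F)nc1N1CCC[C@H]1C(=O)N(C)C)c1ccc(NS(C)(=O)=O)c(F)c1` is reported in this assay as "not active" (no number reported), so no number stands for it, and no measured step to it can be counted. Compound 3 `C[C@H](C(=O)NCc1ccc(C(F)(F)F)nc1N1CCC(c2ccccc2)CC1)c1ccc(NS(C)(=O)=O)c(F)c1` is not yet measured; it differs from compound 2 in one place: 4-phenylpiperidin-1-yl in place of 2-(dimethylcarbamoyl)pyrrolidin-1-yl on an aromatic carbon. With no number for compound 2, the size of this step cannot be given, but the direction is expected to be toward stronger inhibition, since compound 2 is reported as "not active" (no number reported) while compound 1, which carries a different group at the same place, reaches 21.3 nM. For compound 3 an expected value in this assay is 60 nM, with a plausible range from 10 nM to 600 nM; a report of a limit only remains possible.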

Compound 3, half-maximal inhibitory concentration: 17.4 nM
Compound 3: the middle estimate sits 3.4-fold (0.54 log units) above what was measured; low and high end bracket the measured number.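

Compound 2 has no number in this assay, so the step from compound 2 to compound 3 cannot be read. As far as these compounds go, how much swapping in the 4-phenylpiperidin-1-yl group changes inhibition stays open. Nothing shown here offers an explanation for the result.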